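The source may report more compounds than this note shows. Statements on the series, on what has been measured and on what is new or still open speak of the compounds shown alone.

Measured so far in a functional assay on THP-1 cells (Homo sapiens) for antiproliferative activity, tested at 20 uM; on this read-out higher numbers stand for a stronger effect at the one concentration tested and lower numbers for a weaker effect:
Compound 1 `CC(=O)Oc1ccc(CONC(=O)c2ccc(CS(=O)(=O)Nc3ccc4cc(C)c(=O)n(C)c4c3)cc2)cc1`: 1%
Compound 2 `COc1ccc(C(=O)NOCc2ccccc2)cc1S(=O)(=O)Nc1ccc2c(c1)cc(C)c(=O)n2C`: 20%

Compound 2 stands highest of the two numbers; compound 1 lies a gap below it that is beyond the usual scatter. The two compounds differ in more than one place, so nothing is traced to a single change between them.

Compound 3 `COc1ccc(C(=O)NOCc2ccc(OC(C)=O)cc2)cc1S(=O)(=O)Nc1ccc2c(c1)cc(C)c(=O)n2C` differs from compound 2 by acetoxy in place of hydrogen on an aromatic carbon. For the measured compounds named here, no measured pair shows this change alone. The step of a number 5 percentage points lower from compound 2 to compound 3 (within the scatter) is expected to be small, at most a slight fall, within the scatter. Compound 3 is thus estimated at 15%, ranging from 0% to 35%.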

Compound 3, a percentage reported as inhibition, at one concentration (the size of the read-out at that concentration, not a potency): 3%
Estimate against measurement, compound 3: 12 percentage points above, and the stated range covers the measured number.
By their numbers in this assay, from the lowest: compounds 1 and 3 (each within the scatter of the next); then compound 2.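

In this assay, for the compounds shown here, acetoxy in place of hydrogen on the aromatic carbon para to a large group, the change of benzyl to 4-acetoxybenzyl, gives a number 17 percentage points lower from compound 2 to compound 3 (beyond the scatter) and is the only single change that can be read here. This position is therefore not indifferent to substitution, at least for acetoxy on this compound. Nothing shown accounts for the fall.

On these data alone, it remains open whether the fall is particular to acetoxy or extends to other groups at this place. A hydroxyl, an amine or a methoxy group there could stand closer to compound 2 or to compound 3.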